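The source may hold more compounds than are shown below. What is called first, only, known or untested is meant among the compounds shown, and "the series" means these compounds.

Compound 1 `Cc1ccc(NC2=CC(=O)c3c(nc4n3[C@H]3OC[C@@H](O)[C@H]3OC4)C2=O)cc1` carries a (4-methylphenyl)amino group on the shared core. In a functional assay on ECa-109 cells for inhibition, with ECa-109 cell line (Homo sapiens) as the target, read by sulforhodamine B assay (a higher number here means a weaker inhibitor, a lower number a stronger inhibitor), compound 1 gives > 4000 nM, which is a limit of the assay rather than a number. Compound 2 `CCOc1ccc(NC2=CC(=O)c3c(nc4n3[C@H]3OC[C@@H](O)[C@H]3OC4)C2=O)cc1` gives > 4000 nM in this assay, again a limit. Compound 3 `CCCc1ccc(NC2=CC(=O)c3c(nc4n3[C@H]3OC[C@@H](O)[C@H]3OC4)C2=O)cc1` gives > 4000 nM in this assay, also a limit. The steps a step that the two limits leave unreadable from compound 1 to compound 2, a step that the two limits leave unreadable from compound 1 to compound 3 and a step that the two limits leave unreadable from compound 2 to compound 3 cannot be sized, since (the limit of > 4000 nM in this assay, at which 3 of the 3 values shown sit). Compound 4 `CCCN(CCC)C1=CC(=O)c2c(nc3n2[C@H]2OC[C@@H](O)[C@H]2OC3)C1=O` differs from compound 1 by dipropylamino in place of (4-methylphenyl)amino on a double-bonded ring carbon. Within the data shown here, none of the measured steps touches that change, and all three values sit at the limit, so the expected step that the limit leaves unreadable from compound 1 to compound 4 carries no readable direction. Compound 4 is therefore estimated at 6000 nM, between 2000 nM and 20000 nM, most likely reported again as a limit.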

Compound 4, half-maximal inhibitory concentration: > 16000 nM
Compound 4: only a limit was reported (the forecaster's own chance of this, stated with the estimate: 70%); at least 2.6-fold (0.42 log units) between middle value and limit.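

Compound 1 and compound 4 are both reported only as limits in this assay, and the step between them cannot be read. The compounds shown leave open whether dipropylamino in place of (4-methylphenyl)amino changes inhibition at all.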